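The compounds below may be only part of what the source reports. "The series", "measured", "known", "first", "only" and "open" are said of these compounds alone.

Measured so far in a physicochemical assay for solubility; on this read-out higher numbers stand for higher solubility and lower numbers for lower solubility:
- Compound 1 `CNC(=O)c1cc(C(=O)NC2CC2)cc2c1OC[C@H]2c1cccc(F)c1`: >= 175 ug/mL (a limit)
- Compound 2 `CNC(=O)c1cc(C(=O)NC2CC2)cc2c1OC[C@H]2c1ccccc1`: >= 190 ug/mL (a limit)

Compound 2 stands at >= 190 ug/mL in this assay, and this is a limit of the assay, not a number. Compound 3 `CNC(=O)c1cc(C(=O)NC2CC2)cc2c1OC[C@H]2c1ccc(F)cc1` differs from compound 2 by fluoro in place of hydrogen on an aromatic carbon: phenyl to 4-fluorophenyl, with fluoro in place of hydrogen on an aromatic carbon, para to a large group.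

Going by the values given here, only one measured step bears on this change: a step that the two limits leave unreadable from compound 1 to compound 2. It is the same kind of exchange, run in the opposite sense and not at the same carbon, so it gives no size to carry over. Compound 1 keeps a fluoro and gives >= 175 ug/mL, which is again a limit. On that basis, no step beyond the scatter is expected in this assay, in either direction. The estimated step is an at least 1.0-fold lower number from compound 2 to compound 3 (0.02 log units; that floor lies within the scatter). A report of compound 3 as a limit only would be no surprise. The expected value for compound 3 is 180 ug/mL, with an estimated range from 90 ug/mL to 300 ug/mL.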

Compound 3, solubility: 40 ug/mL
Estimate against measurement, compound 3: 4.5-fold (0.65 log units) above; measured number outside the range, below it.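

Fluoro in place of hydrogen on this aromatic carbon, para to a large group, is not neutral in this assay: phenyl to 4-fluorophenyl gives an at least 4.7-fold lower number from compound 2 to compound 3 (0.67 log units; beyond the scatter). The same atom count with the fluoro placed differently also separates the two fluorinated compounds, since 4-fluorophenyl in place of 3-fluorophenyl gives an at least 4.3-fold lower number from compound 1 to compound 3 (0.64 log units; beyond the scatter), so within these three compounds the presence of fluoro alone does not set the read-out and its place on the ring does. Both steps start from limits of the assay and give only a minimum size, while the step between the two limits themselves cannot be read, so the earlier pair offered no such contrast.

Nothing measured in this set gives a cause for the lower number of compound 3. Going by these compounds, it remains open whether a chloro, a methoxy or an amine on the same aromatic carbon would follow the 4-fluorophenyl compound or stay with the unsubstituted phenyl of compound 2, and whether this sensitivity to the fluoro's place holds on other versions of the shared core.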